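Fluorine added to a methoxy-substituted styryl sulfone

A few compounds are considered here, and "the series" means these few. Any claim that something is new, unique, unknown or untested is made for them only; others in the source may bear on it.

Two vinyl sulfones carrying a methoxybenzyl group have been tested in a functional assay on DLD-1 cells (Homo sapiens) for antiproliferative activity, read by trypan blue exclusion; on this read-out higher numbers stand for weaker inhibition and lower numbers for stronger inhibition. Compound 1 `COc1ccc(CS(=O)(=O)/C=C/c2ccc(Cl)cc2)cc1` gives 3000 nM. Compound 2 `COc1ccc(CS(=O)(=O)/C=C/c2ccccc2OC)cc1` gives 7500 nM, the highest of the two numbers; its nearest neighbour is compound 1, whose number is lower by a margin beyond the scatter. From compound 2 the step leads to compound 3 `COc1ccc(CS(=O)(=O)/C=C/c2ccc(F)cc2OC)cc1`, in which the change is fluoro in place of hydrogen on an aromatic carbon. Among the measured compounds shown here, no step of this kind has been measured here, so the direction rests on what the two numbers show: compound 1, which carries a halogen on its ring, gives a lower number than compound 2. A modest step toward stronger inhibition is therefore expected, a 1.7-fold lower number from compound 2 to compound 3 (0.22 log units; within the scatter), though a result within the scatter would not surprise. Compound 3 is estimated at 4500 nM in this assay, with a range from 1500 nM to 13000 nM.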

Compound 3, half-maximal inhibitory concentration: 15000 nM
Beside the measured number, compound 3's estimate is 3.3-fold (0.52 log units) below it; the measured number lies above the stated range.
By their numbers in this assay, from the lowest: compound 1; then compounds 2 and 3 (each within the scatter of the next).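

Placing a fluoro group on this aromatic carbon, para to a large group and meta to a methoxy group, gives a 2.0-fold higher number from compound 2 to compound 3 (0.30 log units; within the scatter) in this assay, so this single change leaves compound 3 indistinguishable from compound 2 on this read-out. Among the compounds shown here, this is the first step in the set that changes one place only, and it gives no sign that fluoro in place of hydrogen at this position brings stronger inhibition. No available evidence bears on the outcome of this step.

On these data alone, whether an amine, a carboxylic acid or a longer chain at this same carbon would shift the number beyond the scatter remains open. Also open, as far as these compounds go, is what the methoxy group meta to this position contributes to the activity of the shared core.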